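The source may report more compounds than this note shows. Statements on the series, on what has been measured and on what is new or still open speak of the compounds shown alone.

Working notes on the series. Compound 1 `COc1cc(-c2nnc(SCC(=O)c3ccc(Br)cc3)n2N)cc(OC)c1OC` gives 10400 nM in a functional assay on HeLa cells (Homo sapiens) for antiproliferative activity, read by MTT assay, with a stated time of 48 h; a lower number here means a stronger inhibitor, a higher number a weaker inhibitor. Compound 2 `COc1cc(-c2nnc(SCC(=O)c3ccc(F)cc3)n2N)cc(OC)c1OC` gives 20900 nM in this assay; the step of a 2.0-fold higher number from compound 1 to compound 2 (0.30 log units; within the scatter) is a halogen swap on the aryl ketone. Compound 3 `COc1cc(-c2nnc(SCC(=O)Nc3ccccc3C)n2N)cc(OC)c1OC` carries an anilide in place of the aryl ketone. In this assay compound 3 reports > 100000 nM, which is a limit of the assay and not a number, so compound 3 stands only at a bound on the numbers shown (the limit of > 100000 nM in this assay, at which 1 of the 3 values shown sits). The steps of an at least 9.6-fold higher number from compound 1 to compound 3 (0.98 log units; beyond the scatter) and an at least 4.7-fold higher number from compound 2 to compound 3 (0.67 log units; beyond the scatter) both run toward weaker inhibition.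

Compound 4 `COc1cccc(NC(=O)CSc2nnc(-c3cc(OC)c(OC)c(OC)c3)n2N)c1` differs from compound 3 by 3-methoxyphenyl in place of 2-methylphenyl on an amide-type nitrogen. For the measured compounds named here, no measured step changes the substituent on the anilide ring itself; the nearest comparison is the aryl substituent swap a 2.0-fold higher number from compound 1 to compound 2 (0.30 log units; within the scatter), which stayed within the scatter, while both anilide steps an at least 9.6-fold higher number from compound 1 to compound 3 (0.98 log units; beyond the scatter) and an at least 4.7-fold higher number from compound 2 to compound 3 (0.67 log units; beyond the scatter) ended at the limit. The step that the limit leaves unreadable from compound 3 to compound 4 is therefore expected to show no change beyond the scatter, most likely another limit. The estimate for compound 4 in this assay is 150000 nM, expected between 50000 nM and 500000 nM.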

Compound 4, half-maximal inhibitory concentration: 4020 nM
Compound 4: middle estimate off by 37-fold (1.57 log units), on the high side, and the stated range ends above it.
By their numbers in this assay, from the lowest: compound 4; then compounds 1 and 2 (each within the scatter of the next). At a limit, above all of these: compound 3.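

On the amide-type nitrogen, 3-methoxyphenyl in place of 2-methylphenyl gives an at least 24-fold lower number from compound 3 to compound 4 (1.39 log units; beyond the scatter) in this assay, so the anilide series is not uniformly inactive, and the loss seen earlier belongs to compound 3 and not to every anilide. Against the aryl ketones, a 5.2-fold lower number from compound 2 to compound 4 (0.72 log units; beyond the scatter) and a 2.6-fold lower number from compound 1 to compound 4 (0.41 log units; beyond the scatter) both run toward stronger inhibition, the opposite direction to the earlier anilide steps. The first step is only a bound, as compound 3 sits at a limit and not at a number: the limit of > 100000 nM in this assay, at which 1 of the 4 values shown sits.

The change swaps the methyl group for a methoxy group and alters the substituted ring position in one step, and the compounds shown do not separate these two differences. On these data alone, an unsubstituted phenyl on the same nitrogen, or a hydroxyl or amine in place of the methoxy group, remains open.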